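This account rests on a few compounds, and the source may have more. Where it says the series, first, only, none or still open, it means among the compounds named here.

Measured in an assay on HEK293 cells for displacement of a labelled ligand from Neuronal acetylcholine receptor; alpha3/beta4 (Homo sapiens), read by scintillation counting, with a stated time of 120 min; a lower number here means a stronger inhibitor, a higher number a weaker inhibitor:
compound 1 `FCCOc1cccc(-c2cn([C@H]3CN4CCC3CC4)nn2)c1`: 558 nM
compound 2 `FCCCOc1cccc(-c2cn([C@H]3CN4CCC3CC4)nn2)c1`: 1630 nM
compound 3 `FCCCOc1cccc(-c2cn([C@@H]3CN4CCC3CC4)nn2)c1`: 19.5 nM

Compound 2 and compound 3 carry the same atoms and bonds; they differ only as the two compounds have the same atoms and bonds; at least one stereo element is drawn with a configuration in one of them and without one in the other: 1 of 3 stereo elements differ; a stereocentre at a saturated ring carbon is drawn R in compound 2 and S in compound 3 describes, and the step in this assay is an 84-fold lower number from compound 2 to compound 3 (1.92 log units; beyond the scatter), which goes with the fact that one of compounds 2 and 3 is drawn with a defined configuration and the other without, at the place where they differ. The change from compound 2 to compound 1 is fluoro in place of fluoromethyl on a saturated chain carbon, two bonds along the chain from an oxygen on an aromatic ring, and in this assay it gave a 2.9-fold lower number from compound 2 to compound 1 (0.47 log units; beyond the scatter).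

Compound 4 `FCCOc1cccc(-c2cn([C@@H]3CN4CCC3CC4)nn2)c1` has not been measured. It differs from compound 3 by fluoro in place of fluoromethyl on a saturated chain carbon, two bonds along the chain from an oxygen on an aromatic ring, the same change at the same place as from compound 2 to compound 1. In this assay compound 4 is expected to show a 2.8-fold lower number from compound 3 to compound 4 (0.44 log units; beyond the scatter), beside a 2.9-fold lower number from compound 2 to compound 1 (0.47 log units; beyond the scatter), resting on that single earlier step. Compound 4 is therefore estimated at 7 nM, likely between 2.5 nM and 20 nM.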

Compound 4, inhibition constant: 11.8 nM
For compound 4 the middle estimate is 1.7-fold (0.23 log units) below the measured one; measured number inside the range.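

In this assay, shortening 3-fluoropropoxy to 2-fluoroethoxy gave a 1.7-fold lower number from compound 3 to compound 4 (0.22 log units; within the scatter), and this step agrees with the earlier one: the same change on two cores in this assay, a 2.9-fold lower number (0.47 log units; beyond the scatter) from compound 2 to compound 1 and a 1.7-fold lower number (0.22 log units; within the scatter) from compound 3 to compound 4, 1.8-fold (0.25 log units) apart, within the scatter of two such steps. The stereocentre at the saturated ring carbon still gives a large step with the shorter chain, a 47-fold lower number from compound 1 to compound 4 (1.67 log units; beyond the scatter), and that step goes with: the fact that one of compounds 1 and 4 is drawn with a defined configuration and the other without, at the place where they differ. For the compounds shown here, the change thus carried over between these two cores without a detectable difference, but this rests on only two pairs whose cores differ at that one stereocentre, and it does not show that the change would carry to a core differing in any other way.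

The compounds shown leave open how a longer chain, such as 4-fluorobutoxy, would read in this assay. They also leave open what a hydroxyl in place of the fluorine would do.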